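A few compounds are considered here, and "the series" means these few. Any claim that something is new, unique, unknown or untested is made for them only; others in the source may bear on it.

Working notes on a small set of three measured compounds and one still to be measured in a functional assay on PC-3 cells (Homo sapiens) for cytotoxicity, read by MTT assay, with a stated time of 72 h; on this read-out higher numbers stand for weaker inhibition and lower numbers for stronger inhibition. Compound 1 `COc1cc(/C=C/c2cc(C)no2)ccc1O` gives 20900 nM in this assay. Compound 3 `CC(=O)CC(=O)/C=C/c1ccc(O)cc1` gives 20200 nM in this assay, a number sitting within the scatter of compound 1, so no order between the two can be read. Compound 2 `Cc1cc(/C=C/c2ccc(O)cc2)[nH]n1` gives 48100 nM in this assay. Compound 1 thus stands second highest of the three numbers, with compound 3 as its nearest neighbour and compound 2 as the furthest, beyond the scatter.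

Compound 4 `Cc1cc(/C=C/c2ccc(O)c(O)c2)on1` has not been measured. It differs from compound 1 in one place: hydrogen in place of methyl on an oxygen on an aromatic ring. Cut one bond further out, the change reads methoxy to hydroxy. Going by the values given here, no pair of measured compounds carries this change, so the set itself gives no size for it. The step is expected to be modest, toward a lower number in this assay, but not clearly beyond the scatter; the expected step is a 1.5-fold lower number from compound 1 to compound 4 (0.17 log units; within the scatter). Compound 4 is estimated at 14000 nM, with a range of 5000 nM to 40000 nM.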

Compound 4, half-maximal inhibitory concentration: 3300 nM
The estimate for compound 4 lay 4.2-fold (0.63 log units) above the measured number; the whole stated range lies above it.
By their numbers in this assay, from the lowest: compound 4; then compounds 3 and 1 (each within the scatter of the next); then compound 2.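

In this assay, going by these compounds alone, the change from methoxy to hydroxy is the first step that can be sized, and it reads a 6.3-fold lower number from compound 1 to compound 4 (0.80 log units; beyond the scatter) on this oxygen on an aromatic ring. Within the data shown here, until now no two compounds differed in one place, so the set said nothing about this position; it now shows that replacing one methyl with hydrogen here is enough to move the number clearly. Nothing at hand accounts for the step, so only its size is recorded.

Whether the free hydroxy matters or the loss of methyl alone is enough stays open, since an ethyl or a longer chain on this oxygen, or an amine in its place, is not among the compounds shown. On these data alone, the step is also known on the core of compound 1 alone, so whether it holds on other cores remains unknown.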